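The compounds below may be only part of what the source reports. "The series", "measured", "known", "first", "only" and "open" are said of these compounds alone.

The measured compounds:
Compound 1, `CCOc1cc(NC(=O)C2(NC(=O)c3ccc4c(C5CCCC5)c(-c5ncc(Cl)cn5)n(C)c4c3)CCC2)ccc1/C=C/C(=O)OCOP(=O)(O)O`, gives 0.15 h in an ADME assay (liver) for pharmacokinetics, with Liver microsome (Rattus norvegicus) as the target, using microsomes; on this read-out lower numbers stand for a shorter-lived compound and higher numbers for a longer-lived compound.
Compound 2, `CCCCCCOC(=O)/C=C/c1ccc(NC(=O)C2(NC(=O)c3ccc4c(C5CCCC5)c(-c5ncc(Cl)cn5)n(C)c4c3)CCC2)cc1OCC`, gives 12.7 h in this assay.
Compound 3, `CCOc1cc(NC(=O)C2(NC(=O)c3ccc4c(C5CCCC5)c(-c5ncc(Cl)cn5)n(C)c4c3)CCC2)ccc1/C=C/C(=O)OCc1ccccc1`, gives 2.17 h in this assay.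

Compound 3 stands second highest of the three numbers. Its nearest neighbour is reached by the step of a 5.9-fold lower number from compound 2 to compound 3 (0.77 log units; beyond the scatter), its furthest by the step of a 14-fold higher number from compound 1 to compound 3 (1.16 log units; beyond the scatter).

Compound 4 is `CCOc1cc(NC(=O)C2(NC(=O)c3ccc4c(C5CCCC5)c(-c5ncc(Cl)cn5)n(C)c4c3)CCC2)ccc1/C=C/C(=O)OCCOCCOC`. It differs from compound 3 by (2-methoxyethoxy)methyl in place of phenyl on a saturated chain carbon bound to an oxygen next to a carbonyl group.

All three measured steps change the group on this same saturated chain carbon, so all of them bear on the question. The steps of an 85-fold higher number from compound 1 to compound 2 (1.93 log units; beyond the scatter) and a 14-fold higher number from compound 1 to compound 3 (1.16 log units; beyond the scatter) show that this position can shift the result by a large amount, and the step of a 5.9-fold lower number from compound 2 to compound 3 (0.77 log units; beyond the scatter) shows that even two groups without oxygen differ by a modest amount. For the measured compounds named here, none of the measured groups carries the two acceptor oxygens of the entering chain without also carrying phosphorus, so the data give no direct guide for the direction. Compound 4 is therefore expected to stay within a modest step of compound 3, estimated as a 1.8-fold lower number from compound 3 to compound 4 (0.26 log units; within the scatter), with a wide range on either side. The estimate for compound 4 is 1.2 h, between 0.3 h and 5 h.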

Compound 4, half-life: 1.07 h
For compound 4 the middle estimate is 1.1-fold (0.05 log units) above the measured one, and the stated range covers the measured number.
By their numbers in this assay, from the lowest: compound 1; then compound 4; then compound 3; then compound 2.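

In this assay, for the compounds shown here, (2-methoxyethoxy)methyl in place of phenyl gives a 2.0-fold lower number from compound 3 to compound 4 (0.31 log units; beyond the scatter) and so shows for the first time how a ring-free group bearing oxygen but no phosphorus behaves at this position, on a saturated chain carbon bound to an oxygen next to a carbonyl group. Set against the all-carbon ester of compound 2, 2-methoxyethoxy in place of butyl gives a 12-fold lower number from compound 2 to compound 4 (1.07 log units; beyond the scatter) as a large step, so the half-life here depends on the atoms within a ring-free chain and not only on whether a ring is present. The phosphorus-bearing group still stands apart, with a 7.1-fold higher number from compound 1 to compound 4 (0.85 log units; beyond the scatter) as the step that remains, so oxygen in the chain does not by itself bring compound 4 down to the number of compound 1.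

Nothing available explains why these groups differ. On these data alone, it remains open whether a shorter 2-methoxyethyl chain, a longer chain of the same repeating ether kind, or a chain ending in an amine or a carboxylic acid would fall nearer compound 4 or nearer compound 2.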